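A few compounds are considered here, and "the series" means these few. Any claim that something is new, unique, unknown or untested is made for them only; others in the source may bear on it.

Of the compounds shown here, three built on one shared core have been tested in a functional assay for antagonist activity at Neuropeptides B/W receptor type 1 (Homo sapiens), read by cAMP accumulation; on this read-out lower numbers stand for stronger inhibition and higher numbers for weaker inhibition. Compound 1 `O=[N+]([O-])c1ccc2[nH]c(-c3ccc(-c4ccccc4)cc3)nc2c1` gives 4880 nM. Compound 2 `O=[N+]([O-])c1ccc2[nH]c(-c3ccc(C(F)(F)F)cc3)nc2c1` gives only a limit of the assay, > 31600 nM. Compound 3 `CC(C)(C)c1ccc(-c2nc3cc([N+](=O)[O-])ccc3[nH]2)cc1` gives 3180 nM, the lowest of the two numbers, although the step of a 1.5-fold lower number from compound 1 to compound 3 (0.19 log units; within the scatter) lies within the scatter. The steps of an at least 6.4-fold higher number from compound 1 to compound 2 (0.81 log units; beyond the scatter) and an at least 9.9-fold lower number from compound 2 to compound 3 (0.99 log units; beyond the scatter) are beyond the scatter, so compound 2 is the weakest of the three. Compound 4 `O=[N+]([O-])c1ccc2[nH]c(-c3ccc(N4CCCC4)cc3)nc2c1` carries pyrrolidin-1-yl in place of tert-butyl on an aromatic carbon. Among the compounds with values here, no measured step exchanges tert-butyl for pyrrolidin-1-yl, so the measured steps bear on it only loosely: tert-butyl and phenyl gave similar numbers, trifluoromethyl a weaker one. The expected step of a 1.1-fold lower number from compound 3 to compound 4 (0.03 log units; within the scatter) is therefore small. Compound 4 is estimated at 3000 nM, between 800 nM and 12000 nM.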

Compound 4, half-maximal inhibitory concentration: 1810 nM
Beside the measured number, compound 4's estimate is 1.7-fold (0.22 log units) above it, within the range that was stated.
By their numbers in this assay, from the lowest: compounds 4, 3 and 1 (each within the scatter of the next, the first and the last beyond it). At a limit, above all of these: compound 2.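

Pyrrolidin-1-yl puts a nitrogen and a non-aromatic ring at this position, and the result stays close to that of tert-butyl, with a 1.8-fold lower number from compound 3 to compound 4 (0.24 log units; within the scatter). The new group does separate from phenyl, although tert-butyl did not, with a 2.7-fold lower number from compound 1 to compound 4 (0.43 log units; beyond the scatter). Compound 2 gives only a limit, so an at least 17-fold lower number from compound 2 to compound 4 (1.24 log units; beyond the scatter) is no exact size: the limit of > 31600 nM in this assay, at which 1 of the 4 values shown sits.

From the compounds shown here alone, whether piperidine, morpholine or an open-chain dimethylamino group at this position would move the number beyond the scatter of compound 4 remains open.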